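Piperidine to methylpiperazine on the acrylamide chain

The source may hold more compounds than are shown below. What is called first, only, known or untested is meant among the compounds shown, and "the series" means these compounds.

Compound 3 `O=C(/C=C/CN1CCCCC1)Nc1cc2c(N3CCc4ccccc43)ncnc2cc1O[C@@H]1CCOC1` gives 4510 nM in a functional assay on PC-3 cells (Homo sapiens) for antiproliferative activity, read by MTT assay, with a stated time of 72 h (a lower number here means a stronger inhibitor, a higher number a weaker inhibitor), the lowest of the three numbers recorded here. Compound 2 `CCN(CC)C/C=C/C(=O)Nc1cc2c(N3CCc4ccccc43)ncnc2cc1O[C@@H]1CCOC1` gives 5780 nM, within the scatter of compound 3, while compound 1 `COc1cc2ncnc(N3CCc4ccccc43)c2cc1NC(=O)/C=C/CN1CCN(C)CC1` gives 9180 nM, a gap beyond the scatter. Compound 4 `CN1CCN(C/C=C/C(=O)Nc2cc3c(N4CCc5ccccc54)ncnc3cc2O[C@@H]2CCOC2)CC1` differs from compound 3 in one place: 4-methylpiperazin-1-yl in place of piperidin-1-yl on a saturated chain carbon bound to a double-bonded chain carbon. For the measured compounds named here, the only measured step that bears on the amine at this position, a 1.3-fold lower number from compound 2 to compound 3 (0.11 log units; within the scatter), moved the number little, and compound 1, which carries the same 4-methylpiperazin-1-yl but a different ether on the shared core, sits only moderately higher. Compound 4 is therefore expected to give about 5500 nM (range 2500 nM to 12000 nM), a step of a 1.2-fold higher number from compound 3 to compound 4 (0.09 log units; within the scatter) expected to stay within the scatter.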

Compound 4, half-maximal inhibitory concentration: 4210 nM
For compound 4 the middle estimate is 1.3-fold (0.12 log units) above the measured one; low and high end bracket the measured number.
By their numbers in this assay, from the lowest: compounds 4, 3, 2 and 1 (each within the scatter of the next, the first and the last beyond it).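

With 4-methylpiperazin-1-yl in place of piperidin-1-yl, this assay shows a 1.1-fold lower number from compound 3 to compound 4 (0.03 log units; within the scatter) and, with the same group in place of diethylamino, a 1.4-fold lower number from compound 2 to compound 4 (0.14 log units; within the scatter) on this saturated chain carbon, so the three amines stand level. For the compounds shown here, the only step here beyond the scatter lies at the ether on the shared core: with 4-methylpiperazin-1-yl held fixed, oxolan-3-yl in place of methyl gives a 2.2-fold lower number from compound 1 to compound 4 (0.34 log units; beyond the scatter) as a modest change.

As far as these compounds go, whether morpholin-4-yl, a primary amine or a longer chain would also stay level remains open. Nothing available explains these numbers.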